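Aryl exchange at the double-bonded chain carbon: compound 4

A few compounds are considered here, and "the series" means these few. Any claim that something is new, unique, unknown or untested is made for them only; others in the source may bear on it.

Values in a functional assay on DU-145 cells (Homo sapiens) for inhibition, read by trypan blue exclusion, with a stated time of 96 h; on this read-out higher numbers stand for weaker inhibition of growth and lower numbers for stronger inhibition of growth:
- compound 1 `O=C(/C(=C\c1ccc(O)cc1O)Sc1ccc(Br)cc1)c1ccc(Cl)cc1`: 50000 nM
- compound 2 `Cc1cc(C)cc(/C=C(/Sc2ccc(Br)cc2)C(=O)c2ccc(Cl)cc2)c1`: 10000 nM
- compound 3 `O=C(/C(=C\c1ccc(Br)cc1)Sc1ccc(Br)cc1)c1ccc(Cl)cc1`: 1000 nM

Compound 3 holds the lowest of the three numbers, with 1000 nM in this assay, and its gaps to both other compounds lie beyond the scatter. The next compound, compound 4 `O=C(/C(=C\c1ccc(F)cc1F)Sc1ccc(Br)cc1)c1ccc(Cl)cc1`, has 2,4-difluorophenyl in place of 4-bromophenyl on a double-bonded chain carbon bound to a double-bonded chain carbon.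

All three measured steps concern this same place, and all lie beyond the scatter. Two are modest, a 5.0-fold lower number from compound 1 to compound 2 (0.70 log units; beyond the scatter) and a 10-fold lower number from compound 2 to compound 3 (1.00 log units; beyond the scatter), and one is large, a 50-fold lower number from compound 1 to compound 3 (1.70 log units; beyond the scatter). The aryl group here has therefore mattered in every measured pair, and compound 3, at 1000 nM, sits at the favourable end of this small set. For the measured compounds named here, no measured step exchanges one halogen-bearing phenyl for another, so the size of the change remains uncertain. A modest rise in the number is expected, though a step within the scatter cannot be ruled out. The expected step is a 2.5-fold higher number from compound 3 to compound 4 (0.40 log units; beyond the scatter). The estimated value for compound 4 is 2500 nM, with an expected range of 600 nM to 10000 nM.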

Compound 4, concentration for 50% growth inhibition: 1000 nM
For compound 4 the middle estimate is 2.5-fold (0.40 log units) above the measured one; low and high end bracket the measured number.
By their numbers in this assay, from the lowest: compounds 3 and 4 (each within the scatter of the next); then compound 2; then compound 1.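

In this assay, for the compounds shown here, the exchange on a double-bonded chain carbon bound to a double-bonded chain carbon gives no change at the digits printed from compound 3 to compound 4 (within the scatter) and is the first step at this position to stay within the scatter, so not every aryl exchange here moves the number. Replacing one bromine with two fluorines, in a different arrangement on the phenyl ring, leaves the two halogen-bearing compounds level, and both stand apart from the others: there is a 10-fold lower number from compound 2 to compound 4 (1.00 log units; beyond the scatter) and a 50-fold lower number from compound 1 to compound 4 (1.70 log units; beyond the scatter) in the same assay, so 2,4-difluorophenyl, like 4-bromophenyl, compares favourably with 3,5-dimethylphenyl and 2,4-dihydroxyphenyl. No supporting data bear on why these two groups give matching numbers.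

As far as these compounds go, whether a phenyl ring carrying an amine or a carboxylic acid, or a longer chain in place of the aryl group, would stay level with compound 3 and compound 4 remains open. The rest of the shared core is identical in all four compounds, so these data say nothing about how changes elsewhere would combine with the aryl group at this position.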